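Thioether acid series: methoxymethyl analogue of compound 3 pending

A few compounds are considered here, and "the series" means these few. Any claim that something is new, unique, unknown or untested is made for them only; others in the source may bear on it.

Measured in an assay on HEK293 cells for inhibition of solute carrier family 22 member 12 (Homo sapiens), read by scintillation counting, with a stated time of 12 min; a lower number here means a stronger inhibitor, a higher number a weaker inhibitor:
Compound 1 `O=C1COc2cccc(SC3(C(=O)O)CCC3)c2N1` gives > 10000 nM, which is a limit of the assay and not a number.
Compound 2 `Nc1ccc2nccc(SC3(C(=O)O)CCC3)c2c1` gives 1790 nM.
Compound 3 `N#CCOc1ccc2nccc(SC3(C(=O)O)CCC3)c2c1` gives 680 nM.

Among the compounds with values here, compound 3 holds the lowest of the two numbers; the nearest is compound 2, the only measured step being a 2.6-fold lower number from compound 2 to compound 3 (0.42 log units; beyond the scatter). Compound 1 sits at the limit of > 10000 nM in this assay, at which 1 of the 3 values shown sits.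

Compound 4 `COCc1ccc2nccc(SC3(C(=O)O)CCC3)c2c1` differs from compound 3 by methoxymethyl in place of cyanomethoxy on an aromatic carbon. Within the data shown here, the single measured step at this position concerns a different exchange, so it bears on the new change only loosely and only as to size: a modest shift at most is expected in this assay. Compound 4 is therefore estimated at 900 nM (range 350 nM to 2500 nM), the expected step being a 1.3-fold higher number from compound 3 to compound 4 (0.12 log units; within the scatter).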

Compound 4, half-maximal inhibitory concentration: 198 nM
For compound 4 the middle estimate is 4.5-fold (0.66 log units) above the measured one; the whole stated range lies above it.
By their numbers in this assay, from the lowest: compound 4; then compound 3; then compound 2. At a limit, above all of these: compound 1.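

At this position on the aromatic carbon, methoxymethyl in place of cyanomethoxy gives a 3.4-fold lower number from compound 3 to compound 4 (0.54 log units; beyond the scatter) and methoxymethyl in place of amino gives a 9.0-fold lower number from compound 2 to compound 4 (0.96 log units; beyond the scatter), so methoxymethyl carries the lowest number of the three groups. The nitrile of cyanomethoxy is therefore not required for a low number here. Nothing measured in these compounds gives a cause for either step.

Going by these compounds, whether hydroxymethyl, ethoxymethyl or a longer ether chain at this position moves the number further remains open. So does the effect of an amine at the end of such a chain.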